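Replacing carboxy with hydroxy in compound 4

A few compounds are considered here, and "the series" means these few. Any claim that something is new, unique, unknown or untested is made for them only; others in the source may bear on it.

Measured so far in an ADME assay on HEK293 cells (Homo sapiens) for cytotoxicity, read by CCK-8 assay, with a stated time of 48 h (a higher number here means a weaker inhibitor, a lower number a stronger inhibitor), with these results:
- compound 1 `COc1ccc(/C=C\c2cc(OC)c(OC)c(OC)c2)cc1OCc1ccc(CNC(C)(C)C(=O)O)cc1` gives > 50000 nM as a limit of the assay
- compound 2 `COc1ccc(/C=C\c2cc(OC)c(OC)c(OC)c2)cc1OCc1ccc(CN2CCCC[C@@H]2C(=O)O)cc1` gives 42000 nM as a number
- compound 3 `COc1ccc(/C=C\c2cc(OC)c(OC)c(OC)c2)cc1OCc1ccc(CN2CC[C@H](C(=O)O)C2)cc1` gives > 50000 nM as a limit of the assay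

Compound 3 therefore offers no number, only a limit. It shares with compound 1 the limit of > 50000 nM in this assay, at which 2 of the 3 values shown sit, and only compound 2 has a measured number.

Compound 4 `COc1ccc(/C=C\c2cc(OC)c(OC)c(OC)c2)cc1OCc1ccc(CN2CC[C@H](O)C2)cc1` differs from compound 3 by hydroxy in place of carboxy on a saturated ring carbon in short, hydroxy in place of carboxy on a saturated ring carbon, which turns 3-carboxypyrrolidin-1-yl into 3-hydroxypyrrolidin-1-yl.

Three measured steps lie nearby: an at least 1.1-fold lower number from compound 1 to compound 2 (0.07 log units; that floor lies within the scatter) then an at least 1.1-fold higher number from compound 2 to compound 3 (0.07 log units; that floor lies within the scatter) and finally a step that the two limits leave unreadable from compound 1 to compound 3 as the unreadable one. Each swaps one carboxy-bearing group for another, so none of them removes the carboxy and none measures this change directly.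

For the measured compounds named here, since all three compounds carry the carboxy and compound 2 gives 42000 nM as the only number, the expectation rests on little. A move towards a lower number in this assay is expected, with a real chance of another limit. The expected size is an at least 2.0-fold lower number from compound 3 to compound 4 (0.30 log units; that floor lies within the scatter) as estimated here. Compound 4 is expected at 25000 nM by this estimate, within an estimated range from 6000 nM to 60000 nM as its likely span.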

Compound 4, half-maximal inhibitory concentration: > 50000 nM
Compound 4 ended at the assay's limit; the forecaster's own chance of this, stated with the estimate: 35%; middle value at least 2.0-fold (0.30 log units) from the limit.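

In this assay compound 4 gives > 50000 nM, which is a limit of the assay and not a number. Compound 4 is the only compound shown without a carboxy, and losing that group does not take it away from the value shared by most of the series: the limit of > 50000 nM in this assay, at which 3 of the 4 values shown sit. The one readable step is an at least 1.1-fold higher number from compound 2 to compound 4 (0.07 log units; that floor lies within the scatter), while the steps to compound 4 from compound 3 and from compound 1 cannot be read, as each joins two limits.

As far as these compounds go, the size of the change from carboxy to hydroxy therefore stays unknown, and so does whether it moves the number at all. An amine or a methoxy group on the same saturated ring carbon could show whether any group at this place gives a measured number in this assay.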